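This account rests on a few compounds, and the source may have more. Where it says the series, first, only, none or still open, it means among the compounds named here.

Working notes on the step from compound 1 (`COC(=O)Nc1cc(-c2ccc(OC[C@@](C)(N)CC(C)C)c(C)c2)ccn1`) to compound 4 (`COC(=O)Nc1cc(-c2ccc(OC[C@@](C)(N)CC(C)C)c(C3CC3)c2)ccn1`). In an ADME assay on microsomes from liver (Mus musculus) for metabolic stability, read by LC-MS, using NADPH, with a stated time of 10 min, tested at 0.5 uM (on this read-out lower numbers stand for a less stable compound and higher numbers for a more stable compound), compound 1 gives 75% as its reading, compound 2 (`COC(=O)Nc1cc(-c2ccc(OC[C@@](C)(N)CC(C)C)c(C)c2C)ccn1`) gives 70% as its reading and compound 3 (`CC(=O)Nc1cc(-c2cc(F)c(OC[C@@H](N)CC(C)C)cc2F)ccn1`) gives 70% on the same scale. Compound 1 therefore stands within the usual scatter of both other compounds, and these readings do not separate the three.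

Compound 4 is still unmeasured and carries cyclopropyl in place of methyl on an aromatic carbon. Going by the values given here, no measured compound carries cyclopropyl, so the series holds no direct precedent for this exchange.

Among the compounds with values here, one measured step bears on it, and only loosely: a number 5 percentage points lower from compound 1 to compound 2 (within the scatter) for methyl in place of hydrogen on an aromatic carbon, which is a different exchange. Resting on that single small step from compound 1 to compound 2, no change beyond the scatter is expected in this assay, with a slight lean towards a lower number. The expected step is a number 7 percentage points lower from compound 1 to compound 4 (within the scatter) and remains an estimate. For compound 4 the estimated reading is 68% with an expected range from 50% to 80% for repeat measurements.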

Compound 4, percent of the compound remaining: 33%
Compound 4: middle estimate off by 35 percentage points, on the high side, and the stated range ends above it.
By their numbers in this assay, from the lowest: compound 4; then compounds 2, 3 and 1 (each within the scatter of the next).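

In this assay, going by these compounds alone, cyclopropyl in place of methyl on this aromatic carbon, ortho to the (2-amino-2,4-dimethylpentyl)oxy group, gives a number 42 percentage points lower from compound 1 to compound 4 (beyond the scatter) and so shows that the reading is sensitive to the group at this position, which the earlier compounds did not reveal. Within the data shown here, the only earlier step from compound 1, methyl in place of hydrogen on an aromatic carbon, gives a number 5 percentage points lower from compound 1 to compound 2 (within the scatter) and is a different exchange, so it offers no measure of what a larger group does here. The present exchange swaps one carbon for three and brings in a three-membered ring of carbon only, with no hydrogen-bond donors or acceptors on either side, and nothing measured in this series explains the large step.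

Still open, going by these compounds, is whether the added carbon count or the ring itself goes with the lower number: ethyl and isopropyl would separate the two, and cyclobutyl would extend the ring series. A methoxy group or a chlorine at this position would show whether readings near compound 1 at 75% are confined to methyl or are shared by other small groups.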